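A few compounds are considered here, and "the series" means these few. Any claim that something is new, unique, unknown or untested is made for them only; others in the source may bear on it.

The measured compounds in a functional assay on HEK293 cells for agonist activity at Neuronal acetylcholine receptor; alpha4/beta2 (Homo sapiens), read by FLIPR (on this read-out lower numbers stand for an effect already at smaller amounts and higher numbers for an effect only at larger amounts of compound), are:

Compound 1, `N#Cc1cncc(N2CC[C@@H]3CN[C@@H]3C2)c1`, gives 1900 nM.
Compound 2, `COc1cncc(N2CC[C@@H]3CN[C@@H]3C2)c1`, gives 2700 nM.
Compound 3, `COc1cc(N2CC[C@H]3CN[C@H]3C2)cnc1Br`, gives 21 nM.

Compounds 1 and 2 share a core and differ in one place only: cyano in place of methoxy on an aromatic carbon. This change gave a 1.4-fold lower number from compound 2 to compound 1 (0.15 log units; within the scatter), so the two values show no difference that can be told from the scatter. Compound 3 stands apart from both. How its core differs from that of compound 2 is not broken down here; what the values show is that compound 3 gives a far lower number in this assay than either compound 1 or compound 2, well beyond the scatter in both cases.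

The unmeasured compound 4, `N#Cc1cc(N2CC[C@H]3CN[C@H]3C2)cnc1Br`, is made from compound 3 by the same kind of change: cyano in place of methoxy on an aromatic carbon. The place differs from the earlier case in that the aromatic carbon in compound 3 is ortho to a bromo group, while in compound 2 no such group is described. Because the earlier change gave a 1.4-fold lower number from compound 2 to compound 1 (0.15 log units; within the scatter), the expectation is that the step from compound 3 to compound 4 stays small as well, at about a 1.2-fold lower number from compound 3 to compound 4 (0.07 log units; within the scatter) in this assay. Compound 4 is therefore estimated to give 18 nM in this assay, with an expected range from 7 nM to 50 nM.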

Compound 4, half-maximal effective concentration: 6.1 nM
Compound 4: middle estimate off by 3.0-fold (0.47 log units), on the high side, and the stated range ends above it.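

In this assay, cyano in place of methoxy ortho to a bromo group gave a 3.4-fold lower number from compound 3 to compound 4 (0.54 log units; beyond the scatter), a modest step, and it cannot be told apart from the same change on the other core: the same change on two cores in this assay, a 1.4-fold lower number (0.15 log units; within the scatter) from compound 2 to compound 1 and a 3.4-fold lower number (0.54 log units; beyond the scatter) from compound 3 to compound 4, 2.4-fold (0.38 log units) apart, within the scatter of two such steps. Among the compounds shown here, as far as these two pairs go, the change carried from one core to the other without a difference in size that rises above the scatter, although only the step to compound 4 lies beyond the scatter on its own, while the step to compound 1 lies within it. Two pairs are a narrow base, however: they do not show that the step would hold on any further core, and they do not tell whether the bromo group, present only in compound 3 and compound 4, has any part in the size of the step.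

The compounds shown leave open how other groups at this aromatic carbon, such as a chloro, a methyl or an amide group, would compare with cyano and methoxy. They also leave open whether a core carrying a chloro or a methyl group in place of the bromo group would give a step of similar size for the same change.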